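The source may report more compounds than this note shows. Statements on the series, on what has been measured and on what is new or still open speak of the compounds shown alone.

Three compounds share one core and differ only in the group attached to it. Compound 1 `O=C1O[C@H]([C@@H](O)Cn2cc(CNS(=O)(=O)c3ccc(F)cc3)nn2)C(OCc2ccccc2)=C1OCc1ccccc1` gives 22500 nM in a functional assay on A549 cells (Homo sapiens) for antiproliferative activity, read by MTT assay, with a stated time of 72 h (a lower number here means a stronger inhibitor, a higher number a weaker inhibitor), compound 2 `CCCCCCCCCCc1cn(C[C@H](O)[C@H]2OC(=O)C(OCc3ccccc3)=C2OCc2ccccc2)nn1` gives 6750 nM, and compound 3 `O=C1O[C@H]([C@@H](O)Cn2cc(CNS(=O)(=O)c3ccc(Cl)cc3)nn2)C(OCc2ccccc2)=C1OCc1ccccc1` gives 2870 nM, the lowest of the three numbers. The steps between them are a 3.3-fold lower number from compound 1 to compound 2 (0.52 log units; beyond the scatter), a 7.8-fold lower number from compound 1 to compound 3 (0.89 log units; beyond the scatter) and a 2.4-fold lower number from compound 2 to compound 3 (0.37 log units; beyond the scatter). Compound 4 `COc1ccc(-c2cn(C[C@H](O)[C@H]3OC(=O)C(OCc4ccccc4)=C3OCc3ccccc3)nn2)cc1` carries 4-methoxyphenyl in place of (((4-chlorophenyl)sulfonyl)amino)methyl on an aromatic carbon. The two steps that also exchange the group at this place, a 3.3-fold lower number from compound 1 to compound 2 (0.52 log units; beyond the scatter) and a 2.4-fold lower number from compound 2 to compound 3 (0.37 log units; beyond the scatter), were modest, so a modest move is expected here too, more likely toward a higher number because compound 3 already stands lowest at 2870 nM. Compound 4 is therefore expected to give 5500 nM, within 1500 nM to 18000 nM, an expected step of a 1.9-fold higher number from compound 3 to compound 4 (0.28 log units; within the scatter).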

Compound 4, half-maximal inhibitory concentration: 28300 nM
The estimate for compound 4 lay 5.1-fold (0.71 log units) below the measured number; measured number above the stated range.
By their numbers in this assay, from the lowest: compound 3; then compound 2; then compounds 1 and 4 (each within the scatter of the next).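

In this assay, 4-methoxyphenyl gives the largest step yet seen for an exchange at this place, a 9.9-fold higher number from compound 3 to compound 4 (0.99 log units; beyond the scatter), and it also loses ground against the chain of compound 2, a 4.2-fold higher number from compound 2 to compound 4 (0.62 log units; beyond the scatter). Against the fluoro counterpart of compound 3 it stands level, a 1.3-fold higher number from compound 1 to compound 4 (0.10 log units; within the scatter), so the advantage of compound 3 over compound 4 is confined to the chloro member of the pair. Nothing available explains these steps. The compounds shown leave open how a 4-chlorophenyl group, an amine or a carboxylic acid would stand at this place.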